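The source may report more compounds than this note shows. Statements on the series, on what has been measured and on what is new or still open speak of the compounds shown alone.

Three compounds share one core and differ only in the aromatic ring attached to the carbonyl of their hydrazide arm. Compound 1 `CCNC(=O)[C@H]1O[C@@H](n2cnc3c(NNC(=O)c4ccc(Br)o4)ncnc32)[C@H](O)[C@@H]1O` gives 369 nM in a functional assay on CHO cells for activation of adenosine receptor A2b (Homo sapiens), read by cAMP accumulation; on this read-out lower numbers stand for an effect already at smaller amounts and higher numbers for an effect only at larger amounts of compound. Compound 2 `CCNC(=O)[C@H]1O[C@@H](n2cnc3c(NNC(=O)c4ccco4)nc(Cl)nc32)[C@H](O)[C@@H]1O` gives 210 nM in this assay, and compound 3 `CCNC(=O)[C@H]1O[C@@H](n2cnc3c(NNC(=O)c4sccc4C)nc(Cl)nc32)[C@H](O)[C@@H]1O` gives 340 nM in this assay. Of these three numbers compound 3 is second highest, yet neither gap to a neighbour is beyond the scatter. Among the compounds with values here, the one measured step of the same kind, a 1.6-fold higher number from compound 2 to compound 3 (0.21 log units; within the scatter), exchanged one five-membered aromatic ring for another and stayed within the scatter. Compound 4 `CCNC(=O)[C@H]1O[C@@H](n2cnc3c(NNC(=O)c4cc(C)on4)nc(Cl)nc32)[C@H](O)[C@@H]1O` differs from compound 3 by 5-methyl-1,2-oxazol-3-yl in place of 3-methylthiophen-2-yl on a carbonyl carbon. Because the comparable step a 1.6-fold higher number from compound 2 to compound 3 (0.21 log units; within the scatter) stayed within the scatter, the expected step is a 1.2-fold higher number from compound 3 to compound 4 (0.07 log units; within the scatter). Compound 4 is estimated at 400 nM, within a range from 170 nM to 950 nM.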

Compound 4, half-maximal effective concentration: > 5000 nM
Compound 4: only a limit was reported; the forecaster's own chance of this, stated with the estimate: 5%; at least 12-fold (1.09 log units) between middle value and limit.
By their numbers in this assay, from the lowest: compounds 2, 3 and 1 (each within the scatter of the next). At a limit, above all of these: compound 4.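

On the carbonyl carbon, exchanging one five-membered aromatic ring for another need not be a small change: 5-methyl-1,2-oxazol-3-yl gives an at least 14-fold higher number from compound 3 to compound 4 (1.16 log units; beyond the scatter) and an at least 23-fold higher number from compound 2 to compound 4 (1.37 log units; beyond the scatter), both beyond the scatter, unlike the earlier ring exchange. Among these compounds, only compound 4 carries a ring with 2 hetero atoms. The reading for compound 4 is a limit and not a number: the limit of > 5000 nM in this assay, at which 1 of the 4 values shown sits.

The compounds shown leave open whether the ring nitrogen alone sets this outcome. On these data alone, how a phenyl or 1,3-thiazol-2-yl ring would read on this carbonyl also remains open.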